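Nitrogen substituent change in a two-compound inhibition series

This account rests on a few compounds, and the source may have more. Where it says the series, first, only, none or still open, it means among the compounds named here.

Measured so far:
compound 1 `c1ccc(Cn2c(-c3ccccc3)cc3ccccc32)cc1` — 0%
compound 2 `COCn1c(-c2ccccc2)cc2ccccc21` — 20.2%

In an assay on isolated protein for inhibition of Aromatase (Homo sapiens), read by fluorescence, using NADPH, with a stated time of 30 min, tested at 50 uM (on this read-out higher numbers stand for more inhibition at the one concentration tested (going by the name of the read-out) and lower numbers for less inhibition), compound 2 gives 20.2%, the higher of the two numbers, while compound 1 gives 0%. Compound 3 `CC(C)(C)OC(=O)n1c(-c2ccccc2)cc2ccccc21` differs from compound 2 by tert-butoxycarbonyl in place of methoxymethyl on an aromatic nitrogen. For the measured compounds named here, the one measured step, a number 20.2 percentage points higher from compound 1 to compound 2 (beyond the scatter), altered the group on the same aromatic nitrogen, but neither group involved there resembles tert-butoxycarbonyl, so it bears only loosely on this change. With that modest precedent and no closer comparison, a small step in either direction is expected, a number 5.2 percentage points lower from compound 2 to compound 3 (within the scatter). Compound 3 is therefore estimated at 15%, with a range of 0% to 40%.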

Compound 3, a percentage reported as inhibition, at one concentration (the size of the read-out at that concentration, not a potency): 11.9%
For compound 3 the middle estimate is 3.1 percentage points above the measured one; the range from low to high includes it.
By their numbers in this assay, from the lowest: compound 1; then compounds 3 and 2 (each within the scatter of the next).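

On the aromatic nitrogen, replacing methoxymethyl with the larger tert-butoxycarbonyl, which brings a carbonyl, leaves the read-out in this assay unresolved (a number 8.3 percentage points lower from compound 2 to compound 3 (within the scatter)). Against benzyl, tert-butoxycarbonyl still gives a modest gain (a number 11.9 percentage points higher from compound 1 to compound 3 (beyond the scatter)), so among these three compounds both non-benzyl groups stand clear of benzyl but not of each other. No measured evidence explains this result.

As far as these compounds go, the effect of an amine or a carboxylic acid on a longer chain at this nitrogen remains open. So does the effect of a free ring nitrogen hydrogen in place of these groups.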